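From butyl to cyclopropyl on a triple-bonded carbon

A few compounds are considered here, and "the series" means these few. Any claim that something is new, unique, unknown or untested is made for them only; others in the source may bear on it.

In a functional assay on Z-138 cells (Homo sapiens) for antiproliferative activity, with a stated time of 72 h (on this read-out lower numbers stand for stronger inhibition and higher numbers for weaker inhibition), compound 1 (`CCCC#Cc1cc([C@@H]2O[C@H](CO)[C@@H](O)[C@H]2O)n2ncnc(N)c12`) gives 20 nM and compound 2 (`CCCCC#Cc1cc([C@@H]2O[C@H](CO)[C@@H](O)[C@H]2O)n2ncnc(N)c12`) gives 200 nM, the higher of the two numbers. Compound 3 (`Nc1ncnn2c([C@@H]3O[C@H](CO)[C@@H](O)[C@H]3O)cc(C#CC3CC3)c12`) has cyclopropyl in place of butyl on a triple-bonded carbon. For the measured compounds named here, only one measured step bears on this change, the addition of a methyl to the saturated chain, a 10-fold higher number from compound 1 to compound 2 (1.00 log units; beyond the scatter), which lies beyond the scatter. Compound 3 has no butyl, so a return towards compound 1 is expected, an estimated 6.7-fold lower number from compound 2 to compound 3 (0.82 log units; beyond the scatter). For compound 3 the estimated value is 30 nM, with an expected range from 8 nM to 120 nM.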

Compound 3, half-maximal inhibitory concentration: 20 nM
For compound 3 the middle estimate is 1.5-fold (0.18 log units) above the measured one; the range from low to high includes it.
By their numbers in this assay, from the lowest: compounds 1 and 3 (each within the scatter of the next); then compound 2.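

Replacing butyl with cyclopropyl on the triple-bonded carbon gives a 10-fold lower number from compound 2 to compound 3 (1.00 log units; beyond the scatter), so the higher number seen with butyl does not extend to this ring. Set against the propyl chain, cyclopropyl gives no change at the digits printed from compound 1 to compound 3 (within the scatter), which shows that a three-membered ring of carbon only and propyl read alike at this position in this assay. No measurement available here accounts for this result. Going by these compounds, what remains open is how a larger ring such as cyclobutyl, or a chain ending in an amine, would read at this position.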